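The source may report more compounds than this note shows. Statements on the series, on what has been measured and on what is new or still open speak of the compounds shown alone.

Compound 1 `Cc1cccc(-n2nncc2CN2C(=O)C3(C(C#N)=C(N)Oc4c3c3nc5ccccc5nc3c3ccccc43)c3ccccc32)c1` belongs to a small set sharing one core, with variation only on the aryl group attached to the triazole nitrogen. In a functional assay on HCT-116 cells (Homo sapiens) for antiproliferative activity, read by MTT assay, with a stated time of 48 h (on this read-out lower numbers stand for stronger inhibition and higher numbers for weaker inhibition), compound 1 gives > 50000 nM, which is a limit of the measurement rather than a number. Compound 2 `N#CC1=C(N)Oc2c(c3nc4ccccc4nc3c3ccccc23)C12C(=O)N(Cc1cnnn1-c1ccc(Br)cc1)c1ccccc12` carries 4-bromophenyl on that aromatic nitrogen. In this assay compound 2 gives > 50000 nM, again a limit. Compound 3 `Cc1ccc(-n2nncc2CN2C(=O)C3(C(C#N)=C(N)Oc4c3c3nc5ccccc5nc3c3ccccc43)c3ccccc32)cc1C` carries 3,4-dimethylphenyl there. In this assay compound 3 gives > 50000 nM, also a limit. Consequently none of the steps between them can be read: a step that the two limits leave unreadable from compound 1 to compound 2, a step that the two limits leave unreadable from compound 1 to compound 3 and a step that the two limits leave unreadable from compound 2 to compound 3 all connect two limits, as summarised by the limit of > 50000 nM in this assay, at which 3 of the 3 values shown sit.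

Compound 4 `Cc1ccc(C)c(-n2nncc2CN2C(=O)C3(C(C#N)=C(N)Oc4c3c3nc5ccccc5nc3c3ccccc43)c3ccccc32)c1` is not yet measured. It differs from compound 1 by methyl in place of hydrogen on an aromatic carbon, so that the ring on the aromatic nitrogen reads 2,5-dimethylphenyl. Among the measured compounds shown here, the one measured step of the same kind, a step that the two limits leave unreadable from compound 1 to compound 3, gives no readable size, and the other two steps give none either. Nothing in the set therefore points to a step beyond the scatter in this assay, in either direction, and the most likely outcome is another limit. Compound 4 is accordingly expected to give about 50000 nM, between 30000 nM and 100000 nM. The step this estimate implies, a number no higher from compound 1 to compound 4 (the limit leaves the size open), is expected to be essentially flat.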

Compound 4, half-maximal inhibitory concentration: > 50000 nM
Compound 4 gave a limit, no number; the forecaster's own chance of this, stated with the estimate: 85%; the middle value sits exactly at the limit.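

Compound 4, like compound 1, compound 2 and compound 3, gives only a limit in this assay, so the steps joining compound 4 to the other three cannot be read: the limit of > 50000 nM in this assay, at which 4 of the 4 values shown sit. The compounds shown leave open whether any aryl group on the triazole nitrogen of the shared core would give a measurable number in this assay.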